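A few compounds are considered here, and "the series" means these few. Any claim that something is new, unique, unknown or untested is made for them only; others in the source may bear on it.

Compound 1 `C[C@@]1(c2cc(NC(=O)c3cnc(OCF)cn3)ccc2F)C=C(CF)OC(N)=N1`: 86%
Compound 2 `Cc1cc(C#N)cnc1C(=O)Nc1ccc(F)c([C@]2(C)C=C(CF)OC(N)=N2)c1`: 63%
Compound 3 `C[C@@]1(c2cc(NC(=O)c3cnc(C(F)F)cn3)ccc2F)C=C(CF)OC(N)=N1`: 84%

All three values come from an ADME assay on microsomes from liver (Homo sapiens) for metabolic stability, read by LC-MS, using NADPH, with a stated time of 30 min, tested at 0.1 uM; a higher number here means that more of the compound is left, a lower number that less of the compound is left. Compound 3 gives 84%, which lies within the scatter of compound 1 and clearly above compound 2. The two steps that show this are a number 2 percentage points lower from compound 1 to compound 3 (within the scatter) and a number 21 percentage points higher from compound 2 to compound 3 (beyond the scatter).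

The next compound, compound 4 `C[C@@]1(c2cc(NC(=O)c3ncc(OCF)nc3N)ccc2F)C=C(CF)OC(N)=N1`, differs from compound 3 in one place: 3-amino-5-(fluoromethoxy)pyrazin-2-yl in place of 5-(difluoromethyl)pyrazin-2-yl on a carbonyl carbon. In words, 3-amino-5-(fluoromethoxy)pyrazin-2-yl stands in place of 5-(difluoromethyl)pyrazin-2-yl on a carbonyl carbon.

For the measured compounds named here, two measured steps bear on this. The exchange between fluoromethoxy and difluoromethyl mattered little, as a number 2 percentage points lower from compound 1 to compound 3 (within the scatter) shows, so that part of the change offers no reason to expect a large shift. Going by the values given here, the amino group has no measured precedent here. However, a number 23 percentage points lower from compound 1 to compound 2 (beyond the scatter) shows that a different group on this carbonyl carbon can lower the number.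

A small downward step is therefore expected, a number 12 percentage points lower from compound 3 to compound 4 (beyond the scatter). Compound 4 is estimated at 72%, with an expected range of 55% to 89%.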

Compound 4, percent of the compound remaining: 67%
Compound 4: the middle estimate sits 5 percentage points above what was measured, within the range that was stated.
By their numbers in this assay, from the lowest: compounds 2 and 4 (each within the scatter of the next); then compounds 3 and 1 (each within the scatter of the next).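

In this assay, for the compounds shown here, amino in place of hydrogen on an aromatic carbon is the only change between two compounds, and it gives a number 19 percentage points lower from compound 1 to compound 4 (beyond the scatter), so this one added group is enough to shift the result. Starting from the difluoromethyl compound, the exchange on the carbonyl carbon gives a number 17 percentage points lower from compound 3 to compound 4 (beyond the scatter), which fits the earlier finding that fluoromethoxy and difluoromethyl differ little in this series: a number 2 percentage points lower from compound 1 to compound 3 (within the scatter). The exchange of the 5-cyano-3-methylpyridin-2-yl group gives a number 4 percentage points higher from compound 2 to compound 4 (within the scatter), so two quite different groups on this carbonyl carbon can end up level.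

No measurement shown explains why the amino group lowers the number. From the compounds shown here alone, whether a methylamino or hydroxyl group in place of that amino group would lower it as well remains open.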